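Halogenated anilide variants on the shared triazole core

The source may hold more compounds than are shown below. What is called first, only, known or untested is meant among the compounds shown, and "the series" means these compounds.

Measured compounds and values in an assay on isolated protein (Mus musculus) for inhibition of IL15-IL15 receptor (Homo sapiens), read by resazurin assay, with stated times of 30 min and 2.5 days; a higher number here means a weaker inhibitor, a lower number a stronger inhibitor:
- compound 1, `CN(C(=O)CSc1nnc(Cc2nn(C)c(=O)c3ccccc23)n1C)c1ccc(Cl)cc1Cl`: > 30000 nM
- compound 2, `Cn1c(Cc2nn(C)c(=O)c3ccccc23)nnc1SCC(=O)Nc1ccc(Br)cc1Br`: > 30000 nM
- compound 3, `Cn1c(Cc2nn(C)c(=O)c3ccccc23)nnc1SCC(=O)Nc1ccc(F)cc1F`: "not active" (no number reported)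

The value for compound 1 is a limit of this assay, not a number. The value for compound 2 is likewise a limit. Compound 3 carries no number at all in this assay; it is reported only as inactive, so it cannot be placed relative to the other two beyond the observation that all three sit at or beyond the measurable range, as the limit of > 30000 nM in this assay, at which 2 of the 3 values shown sit, shows.

Compound 4, `Cn1c(Cc2nn(C)c(=O)c3ccccc23)nnc1SCC(=O)Nc1ccc(I)cc1`, is not yet measured. It differs from compound 3 by 4-iodophenyl in place of 2,4-difluorophenyl on an amide-type nitrogen. Among the measured compounds shown here, the only measured step among the three, a step that the two limits leave unreadable from compound 1 to compound 2, is unreadable, so no size or direction for a halogen swap on this anilide can be drawn from it. With every measured value at or beyond the limit, no step beyond the scatter is expected in this assay. Compound 4 is therefore estimated at 30000 nM, with a range of 10000 nM to 100000 nM, and most likely reported only as a limit.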

Compound 4, half-maximal inhibitory concentration: "not active" (no number reported)
Nothing numeric was reported for compound 4; there is nothing to compare the estimate with.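

Compound 4, like compound 3, is reported in this assay only as inactive, without a number, so no new step can be read between them. The compounds shown leave open whether any anilide on the shared core reaches a measurable value, with the numerical entries confined to a limit: the limit of > 30000 nM in this assay, at which 2 of the 4 values shown sit.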